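Notes on the ester-to-hydroxymethyl step

A few compounds are considered here, and "the series" means these few. Any claim that something is new, unique, unknown or untested is made for them only; others in the source may bear on it.

The three measured compounds share one core: compound 1 `C[C@H](O)[C@@H](CCc1ccc(C(F)(F)F)cc1)n1cnc2c(N)ncnc21`, compound 2 `C[C@H](O)[C@@H](CCc1cccc(F)c1)n1cnc2c(N)ncnc21` and compound 3 `COC(=O)c1cccc(CC[C@H]([C@H](C)O)n2cnc3c(N)ncnc32)c1` differ only in the group carried on the aromatic ring at the end of the side chain. In an assay on isolated protein for inhibition of adenosine deaminase (Bos taurus), with a stated time of 5 min (a higher number here means a weaker inhibitor, a lower number a stronger inhibitor), compound 1 gives 5.2 nM, compound 2 gives 1.6 nM, and compound 3 gives 2.2 nM. Compound 3 therefore holds the second highest of the three numbers; compound 2 sits nearest to it, within the scatter, while compound 1 sits furthest, beyond the scatter.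

Compound 4 `C[C@H](O)[C@@H](CCc1cccc(CO)c1)n1cnc2c(N)ncnc21` is the next point in the series, and the change from compound 3 is hydroxymethyl in place of methoxycarbonyl on an aromatic carbon. Among the measured compounds shown here, only one measured step touches the same aromatic carbon, and because a 1.4-fold higher number from compound 2 to compound 3 (0.14 log units; within the scatter) stayed within the scatter, the expected step for compound 4 is one of no clear direction, estimated at a 1.1-fold higher number from compound 3 to compound 4 (0.06 log units; within the scatter). For the measured compounds named here, no measured compound carries a hydroxymethyl, so that group itself has no precedent in this set, and the estimate rests on the single step just named. Compound 4 is accordingly expected to give about 2.5 nM in this assay, with a range from 1 nM to 6.5 nM.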

Compound 4, inhibition constant: 4.6 nM
Compound 4: middle estimate off by 1.8-fold (0.26 log units), on the low side; measured number inside the range.
By their numbers in this assay, from the lowest: compounds 2 and 3 (each within the scatter of the next); then compounds 4 and 1 (each within the scatter of the next).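

At this aromatic carbon, the earlier change from fluoro to methoxycarbonyl gave a 1.4-fold higher number from compound 2 to compound 3 (0.14 log units; within the scatter) in this assay, whereas hydroxymethyl gives a 2.1-fold higher number from compound 3 to compound 4 (0.32 log units; beyond the scatter) and a 2.9-fold higher number from compound 2 to compound 4 (0.46 log units; beyond the scatter), so the position is not indifferent to the group it carries, although both new steps are modest. Relative to methoxycarbonyl, hydroxymethyl has fewer heavy atoms, adds a hydrogen-bond donor and loses the double bond outside the aromatic ring, and these differences arrive together in one step, which cannot separate them. No supporting measurement is available to explain the higher number for compound 4.

The compounds shown leave open which of those differences accounts for the step; a methoxymethyl group, an aminomethyl group or a carboxylic acid on the same aromatic carbon would help to tell them apart. They also leave open whether hydroxymethyl gives a step of similar size on another carbon of the same ring, and whether a longer chain carrying the hydroxyl group follows the same direction.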